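A few compounds are considered here, and "the series" means these few. Any claim that something is new, unique, unknown or untested is made for them only; others in the source may bear on it.

Measured compounds:
compound 1 `CCN1CCc2nc(C#Cc3ccccc3)sc2C1`, 1200 nM in an assay on HEK293 cells for negative allosteric modulation of metabotropic glutamate receptor 5 (Homo sapiens), read by FLIPR, with a stated time of 1 h; a lower number here means a stronger inhibitor, a higher number a weaker inhibitor;
compound 2 `O=C(C1CC(F)C1)N1CCc2nc(C#Cc3ccccc3)sc2C1`, a limit of this assay, > 10000 nM;
compound 3 `COC1CC(C(=O)N2CCc3nc(C#Cc4ccccc4)sc3C2)C1`, likewise a limit, > 10000 nM.

Compound 3 therefore stands at the limit of > 10000 nM in this assay, at which 2 of the 3 values shown sit, with no number of its own. The unmeasured compound 4 `O=C(CC1CCOCC1)N1CCc2nc(C#Cc3ccccc3)sc2C1` differs from it by (oxan-4-yl)methyl in place of 3-methoxycyclobutyl on a carbonyl carbon. Going by the values given here, the steps that bear on this are an at least 8.3-fold higher number from compound 1 to compound 2 (0.92 log units; beyond the scatter) and an at least 8.3-fold higher number from compound 1 to compound 3 (0.92 log units; beyond the scatter), both leading from the ethyl amine to an amide at a limit, while a step that the two limits leave unreadable from compound 2 to compound 3 cannot be read. Compound 4 keeps the amide carbonyl, so the step that the limit leaves unreadable from compound 3 to compound 4 is expected to stay within the scatter and to remain at a limit. Compound 4 is estimated at 15000 nM, between 5000 nM and 50000 nM.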

Compound 4, half-maximal inhibitory concentration: > 10000 nM
Compound 4 was reported as a limit; the forecaster's own chance of this, stated with the estimate: 70%; the middle value does not contradict the limit.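

Compound 4 is a limit in this assay, > 10000 nM, and its steps from compound 2 and compound 3, also limits, cannot be read. The compounds shown leave open how these three amides rank among themselves.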